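This account rests on a few compounds, and the source may have more. Where it says the series, first, only, none or still open, it means among the compounds named here.

In a functional assay (aorta) with Rattus norvegicus as the target (a lower number here means that less compound is needed, a higher number that more compound is needed for the effect), three compounds that share one core have been measured. Compound 1 `COc1ccc(-c2nc(CN)sc2-c2ccc(OC)cc2)cc1` gives 7.7 uM, compound 2 `COc1ccc(-c2nc(CNC(=O)c3cccnc3)sc2-c2ccc(OC)cc2)cc1` gives 8.2 uM, and compound 3 `COc1ccc(-c2nc(CNC(=O)CSC)sc2-c2ccc(OC)cc2)cc1` gives 6 uM. Compound 3 therefore stands within the scatter of both other compounds, as shown by a 1.3-fold lower number from compound 1 to compound 3 (0.11 log units; within the scatter) and a 1.4-fold lower number from compound 2 to compound 3 (0.14 log units; within the scatter).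

The next compound, compound 4 `COc1ccc(-c2nc(C(=O)N3CCOCC3)sc2-c2ccc(OC)cc2)cc1`, has (morpholin-4-yl)carbonyl in place of ((((methylsulfanyl)methyl)carbonyl)amino)methyl on an aromatic carbon. The nearest evidence comes from changes at the amine nitrogen, and all of these steps are small. Alongside the two steps above, there is a 1.1-fold higher number from compound 1 to compound 2 (0.03 log units; within the scatter). None of them replaces the whole chain on the aromatic carbon, so they offer only indirect guidance and the range must stay wide. Given how little a 1.3-fold lower number from compound 1 to compound 3 (0.11 log units; within the scatter) and a 1.4-fold lower number from compound 2 to compound 3 (0.14 log units; within the scatter) moved the number, no step beyond the scatter is expected in this assay, and the expected step is a 1.2-fold higher number from compound 3 to compound 4 (0.07 log units; within the scatter). For compound 4 the estimated value is 7 uM, with an expected range from 2.5 uM to 20 uM.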

Compound 4, concentration for half-maximal effect: < 100 uM
Compound 4: a limit, no number; the forecaster's own chance of this, stated with the estimate: 10%; the middle value lies beyond the limit too.
By their numbers in this assay, from the lowest: compounds 3, 1 and 2 (each within the scatter of the next).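

In this assay compound 4 gives < 100 uM, which is a limit and not a number. For the compounds shown here, no step from compound 1, compound 2 or compound 3 to compound 4 can be read. The compounds shown leave open how (morpholin-4-yl)carbonyl compares with the chains it replaces on the aromatic carbon.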